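Series notes: methyl on the five-membered ring, compound 4

This account rests on a few compounds, and the source may have more. Where it says the series, first, only, none or still open, it means among the compounds named here.

Measured so far:
compound 1 `CCS(=O)(=O)N[C@@H]1CCCc2c1cncc2N1Cc2cc(Cl)ccc2C1=O` — 40 nM
compound 2 `CC(=O)N[C@@H]1CCCc2c1cncc2N1C(=O)c2ccc(Cl)cc2[C@H]1C` — 130 nM
compound 3 `CCC(=O)N[C@@H]1CCCc2c1cncc2N1Cc2cc(Cl)ccc2C1=O` — 28 nM

In an assay on cells for inhibition of cytochrome P450 11B2, mitochondrial (Homo sapiens), read by HTRF (on this read-out lower numbers stand for stronger inhibition and higher numbers for weaker inhibition), compound 3 holds the lowest of the three numbers. The step of a 1.4-fold lower number from compound 1 to compound 3 (0.15 log units; within the scatter) is within the scatter, so compound 1 and compound 3 cannot be separated; compound 2 stands clearly higher. Compound 4 `CCC(=O)N[C@@H]1CCCc2c1cncc2N1C(=O)c2ccc(Cl)cc2[C@H]1C` differs from compound 3 by methyl in place of hydrogen on a saturated ring carbon. Among the measured compounds shown here, no measured step isolates this change: compound 2 carries the same methyl and gives the highest number, but it also differs from compound 3 in the group on the amine nitrogen. The step from compound 1 to compound 3 concerns that amine group, not this ring position. The methyl is therefore expected to weaken inhibition modestly, a 2.1-fold higher number from compound 3 to compound 4 (0.33 log units; beyond the scatter). In this assay compound 4 is estimated at 60 nM, with a range of 25 nM to 150 nM.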

Compound 4, half-maximal inhibitory concentration: 66 nM
Compound 4: the middle estimate sits 1.1-fold (0.04 log units) below what was measured; measured number inside the range.
By their numbers in this assay, from the lowest: compounds 3, 1, 4 and 2 (each within the scatter of the next, the first and the last beyond it).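

Methyl in place of hydrogen on the saturated ring carbon now has a step of its own in this assay (a 2.4-fold higher number from compound 3 to compound 4 (0.37 log units; beyond the scatter)): modest weakening, beyond the scatter. With that ring methyl present, methyl in place of hydrogen on the saturated chain carbon bound to a carbonyl carbon gives no separable change (a 2.0-fold lower number from compound 2 to compound 4 (0.29 log units; within the scatter)). No evidence is available on the ring-methyl step.

Open: how a larger group such as ethyl or a hydroxyl on this ring carbon would read. Also open, from the compounds shown here alone, is whether the ring-methyl step holds with ethylsulfonyl on the amine nitrogen.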